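Aryl swap on the hydrazone carbon of compound 1

The source may report more compounds than this note shows. Statements on the series, on what has been measured and on what is new or still open speak of the compounds shown alone.

Working notes on the series. Of the compounds shown here, two have been measured; both share the same core and differ only in the aryl group attached to the carbon with a double bond to nitrogen. Among the measured compounds shown here, compound 1 `O=C(N/N=C/c1cccc([N+](=O)[O-])c1)Nc1ccc(Oc2ccnc3[nH]ccc23)c(F)c1` is the reference: in a functional assay on A549 cells (Homo sapiens) for antiproliferative activity, read by MTT assay, with a stated time of 72 h (on this read-out lower numbers stand for stronger inhibition and higher numbers for weaker inhibition), compound 1 gives 3640 nM, the lower of the two numbers so far. Compound 2 `CC(C)(C)c1cc(/C=N/NC(=O)Nc2ccc(Oc3ccnc4[nH]ccc34)c(F)c2)cc(C(C)(C)C)c1O` carries a bulkier hydroxyphenyl at the same position, and in this assay compound 2 gives 13600 nM; the gap between the two values lies beyond the scatter, with compound 1 the lower.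

Compound 3 `O=C(N/N=C/c1ccc(O)c(Br)c1)Nc1ccc(Oc2ccnc3[nH]ccc23)c(F)c1` has not been measured. Against compound 1 the single difference is 3-bromo-4-hydroxyphenyl in place of 3-nitrophenyl on a carbon with a double bond to nitrogen. For the measured compounds named here, no step between measured compounds matches this change, so the expectation rests on compound 1 alone. Going by the values given here, since the modification is confined to the aryl at the hydrazone carbon and the entering group is smaller than the one in compound 2, the step of a 1.2-fold lower number from compound 1 to compound 3 (0.08 log units; within the scatter) is expected to be modest, plausibly within the scatter, in either direction. Compound 3 is therefore estimated at 3000 nM in this assay, with a range from 900 nM to 10000 nM.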

Compound 3, half-maximal inhibitory concentration: 9250 nM
Compound 3: middle estimate off by 3.1-fold (0.49 log units), on the low side, within the range that was stated.
By their numbers in this assay, from the lowest: compound 1; then compounds 3 and 2 (each within the scatter of the next).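

In this assay, 3-bromo-4-hydroxyphenyl in place of 3-nitrophenyl gives a 2.5-fold higher number from compound 1 to compound 3 (0.41 log units; beyond the scatter), so this position on the carbon with a double bond to nitrogen responds to a change of aryl even without the di-tert-butyl hydroxyphenyl of compound 2. Among the compounds shown here, compound 3 and compound 2 stand within the scatter of each other, and among the three compounds both rings that carry a hydroxyl give higher numbers than the 3-nitrophenyl of compound 1, with no compound here going against that pattern. No measurement in hand bears on why the number moves with this change.

From the compounds shown here alone, the bromine and the hydroxyl enter together in compound 3, so the step cannot be assigned to either one, and it remains open whether it reflects what they bring or the loss of the nitro group. A hydroxyphenyl without bromine, a bromophenyl without hydroxyl, or an aminophenyl at the same carbon would separate these readings, and would show whether any aryl here gives a lower number than compound 1.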